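Stereocentre drawn R: where compound 4 should fall

The compounds below may be only part of what the source reports. "The series", "measured", "known", "first", "only" and "open" are said of these compounds alone.

Values measured so far in a physicochemical assay for lipophilicity, at pH 7.4; a higher number here means a more lipophilic compound, a lower number a more polar compound
- compound 1 `CC(C)CN(c1cc2ccccc2s1)S(=O)(=O)c1ccc2c(c1)C(=O)CC(C1CCOCC1)O2` gives 4.01
- compound 2 `CCc1ccc(N(CC(C)C)S(=O)(=O)c2ccc3c(c2)C(=O)C[C@@H](C2CCOCC2)O3)cc1` gives 4.2
- compound 3 `CCc1ccc(N(CC(C)C)S(=O)(=O)c2ccc3c(c2)C(=O)CC(C2CCOCC2)O3)cc1` gives 4.21

Compound 3 cannot be separated from either of the other two measured compounds in this assay and the two steps that reach it are a number 0.01 log units higher from compound 2 to compound 3 (within the scatter) and a number 0.20 log units higher from compound 1 to compound 3 (within the scatter) (neither goes beyond what repeat measurements would give).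

Compound 4 `CCc1ccc(N(CC(C)C)S(=O)(=O)c2ccc3c(c2)C(=O)C[C@H](C2CCOCC2)O3)cc1` is still unmeasured. Its difference from compound 3 is this: the two compounds have the same atoms and bonds; at least one stereo element is drawn with a configuration in one of them and without one in the other: 1 of 1 stereo elements differ; a stereocentre at a saturated ring carbon is drawn without a configuration in compound 3 and R in compound 4 (nothing leaves and nothing enters).

One measured step is of the same kind, namely a number 0.01 log units higher from compound 2 to compound 3 (within the scatter) with the fact that one of compounds 2 and 3 is drawn with a defined configuration and the other without, at the place where they differ as the sole difference. Going by the values given here, at that stereocentre compound 2 is drawn S, whereas compound 4 is drawn R. The other measured step puts 4-ethylphenyl in place of 1-benzothiophen-2-yl on a sulfonamide nitrogen, a change that has no counterpart between compound 3 and compound 4, so it carries no weight here.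

Among the compounds with values here, no step beyond the scatter is expected because a number 0.01 log units higher from compound 2 to compound 3 (within the scatter) is the only precedent for this kind of change. The estimated step is a number 0.01 log units lower from compound 3 to compound 4 (within the scatter) and no direction is expected in it.

For compound 4 the expected value is 4.2 (estimated range 4 to 4.4).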

Compound 4, distribution coefficient: 4.24
Compound 4: middle estimate off by 0.04 log units, on the low side; measured number inside the range.
By their numbers in this assay, from the lowest: compounds 1, 2, 3 and 4 (each within the scatter of the next).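

The series now holds both drawn configurations at the stereocentre at a saturated ring carbon, so S and R can be compared directly and not only each against a drawing without a configuration, and in this assay that comparison gives a number 0.04 log units higher from compound 2 to compound 4 (within the scatter). The drawing without a configuration does not stand apart from the R form either, the reading being a number 0.03 log units higher from compound 3 to compound 4 (within the scatter), which completes the set of three drawings of this structure. With 4-ethylphenyl on the sulfonamide nitrogen, this assay therefore gives no reading that separates the drawn configurations at this stereocentre, and the pair that tests this most directly rests on: the fact that compounds 2 and 4 differ only in the configuration as drawn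

Whether the same holds with 1-benzothiophen-2-yl on the sulfonamide nitrogen stays open, as compound 1 is drawn without a configuration and no S or R partner for it is shown. Also open, as far as these compounds go, is whether the two configurations stay inseparable in this assay once the core carries an amine or a carboxylic acid, and whether they can be told apart in any other read-out.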